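This account rests on a few compounds, and the source may have more. Where it says the series, first, only, none or still open, it means among the compounds named here.

Compound 1 `O=C(O)Cc1sc(CS(=O)(=O)c2ccc(Cl)cc2)nc1-c1ccc(Cl)cc1`: 1500 nM
Compound 2 `O=C(O)Cc1sc(C(Cc2ccccc2)c2ccccc2)nc1-c1ccc(Cl)cc1`: 56 nM
Compound 3 `N#Cc1ccc(-c2nc(C(c3ccc(F)cc3)c3ccc(F)cc3)sc2CC(=O)O)cc1`: 150 nM

Of the compounds shown here, three sharing one core have been measured in an in vitro assay on HEK385-7 cells for displacement of a labelled ligand from prostaglandin D2 receptor 2 (Homo sapiens); on this read-out higher numbers stand for weaker inhibition and lower numbers for stronger inhibition. Compound 3 stands second highest of the three numbers. Its nearest neighbour is compound 2, which in this assay gives 56 nM, a lower number beyond the usual scatter. Its furthest neighbour is compound 1, which gives 1500 nM, a higher number beyond the scatter.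

Compound 4 `O=C(O)Cc1sc(C(c2ccc(F)cc2)c2ccc(F)cc2)nc1-c1cn[nH]c1` differs from compound 3 in one place: 1H-pyrazol-4-yl in place of 4-cyanophenyl on an aromatic carbon. Within the data shown here, no pair of measured compounds differing in one place is available, so the size of this kind of change cannot be read from the measured compounds and rests on expectation alone. A moderate step towards a higher number is expected, beyond the scatter, namely a 2.7-fold higher number from compound 3 to compound 4 (0.43 log units; beyond the scatter). Compound 4 is therefore estimated at 400 nM in this assay, with a range from 100 nM to 1600 nM.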

Compound 4, half-maximal inhibitory concentration: 16 nM
Compound 4: middle estimate off by 25-fold (1.40 log units), on the high side, and the stated range ends above it.
By their numbers in this assay, from the lowest: compound 4; then compound 2; then compound 3; then compound 1.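

In this assay, among these compounds, the position next to the ring nitrogen proves sensitive to the group it carries: 1H-pyrazol-4-yl in place of 4-cyanophenyl gives a 9.4-fold lower number from compound 3 to compound 4 (0.97 log units; beyond the scatter), a step beyond the scatter and the first single-place change that can be read. The 4-cyanophenyl group is thus not required here, since a five-membered aromatic ring with fewer heavy atoms and a hydrogen-bond donor goes with the lower number. Nothing measured explains this step.

Going by these compounds, it remains open whether the lower number follows the ring's hydrogen-bond donor or its smaller size, a question that 1-methyl-1H-pyrazol-4-yl or plain phenyl at this position would address. Also open, on these data alone, is whether 1H-pyrazol-4-yl would have the same effect alongside the large group of compound 2 in place of the bis(4-fluorophenyl)methyl group.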